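A hydroxypropyl chain in place of cyclopropyl

The source may hold more compounds than are shown below. What is called first, only, known or untested is meant among the compounds shown, and "the series" means these compounds.

In an assay on isolated protein for antagonist activity at Bile acid receptor (Homo sapiens), read by TR-FRET, with a stated time of 20 min (a higher number here means a weaker inhibitor, a lower number a stronger inhibitor), three compounds have been measured so far:

compound 1 `Cc1ccc(-c2nn(-c3cccc(Cl)c3)cc2C(=O)Nc2ccc(C)c(S(=O)(=O)N3CCOCC3)c2)cc1`: 10.4 nM
compound 2 `Cc1ccc(-c2nn(C(C)C)cc2C(=O)Nc2ccc(C)c(S(=O)(=O)N3CCOCC3)c2)cc1`: 49.1 nM
compound 3 `Cc1ccc(-c2nn(CC3CC3)cc2C(=O)Nc2ccc(C)c(S(=O)(=O)N3CCOCC3)c2)cc1`: 76.9 nM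

Compound 3 holds the highest of the three numbers. Its nearest neighbour is compound 2, and the step of a 1.6-fold higher number from compound 2 to compound 3 (0.19 log units; within the scatter) stays within the scatter, so the two cannot be ordered; the gap to compound 1, a 7.4-fold higher number from compound 1 to compound 3 (0.87 log units; beyond the scatter), lies beyond it. Compound 4 `Cc1ccc(-c2nn(CCCCO)cc2C(=O)Nc2ccc(C)c(S(=O)(=O)N3CCOCC3)c2)cc1` differs from compound 3 by 3-hydroxypropyl in place of cyclopropyl on a saturated chain carbon bound to an aromatic nitrogen. For the measured compounds named here, the steps that bear on this position are those on the aromatic nitrogen: a 4.7-fold higher number from compound 1 to compound 2 (0.67 log units; beyond the scatter), a 7.4-fold higher number from compound 1 to compound 3 (0.87 log units; beyond the scatter) and a 1.6-fold higher number from compound 2 to compound 3 (0.19 log units; within the scatter). The exchange of one saturated substituent for another, isopropyl to cyclopropylmethyl, stayed within the scatter, while only the move away from 3-chlorophenyl went beyond it. Going by the values given here, a hydroxyl-bearing chain has no measured precedent in this set. The step is therefore expected to be a 1.2-fold higher number from compound 3 to compound 4 (0.09 log units; within the scatter), not beyond the scatter, with a wide range to cover the missing precedent. In this assay compound 4 is estimated at 95 nM, with a range from 35 nM to 260 nM.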

Compound 4, half-maximal inhibitory concentration: 130 nM
Compound 4: middle estimate off by 1.4-fold (0.14 log units), on the low side, and the stated range covers the measured number.
By their numbers in this assay, from the lowest: compound 1; then compounds 2, 3 and 4 (each within the scatter of the next, the first and the last beyond it).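

In this assay the first hydroxyl-bearing chain on the aromatic nitrogen gives a 1.7-fold higher number from compound 3 to compound 4 (0.23 log units; within the scatter) and so cannot be told apart from the cyclopropylmethyl of compound 3, even though the ring is lost and a hydrogen-bond donor and acceptor enter. Against isopropyl the same chain gives a 2.6-fold higher number from compound 2 to compound 4 (0.42 log units; beyond the scatter) and does separate, although compound 2 and compound 3 could not be ordered, while a 13-fold higher number from compound 1 to compound 4 (1.10 log units; beyond the scatter) is the largest step so far and leaves compound 1 the strongest inhibitor of the four. No supporting data give a reason for any of these steps.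

The compounds shown leave open how much of this belongs to the hydroxyl and how much to the chain itself. A plain butyl chain, or an amine or a carboxylic acid at the end of the chain, would separate the two.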